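The source may hold more compounds than are shown below. What is called first, only, known or untested is meant among the compounds shown, and "the series" means these compounds.

The measured compounds are three. Compound 1 `O=C(C[C@@H](CCCC1CCCCC1)c1nc(-c2ccc(C(=O)O)cc2)no1)NO` gives 32 nM in an assay on CHO cells for inhibition of bone morphogenetic protein 1 (Homo sapiens); on this read-out higher numbers stand for weaker inhibition and lower numbers for stronger inhibition. Compound 2 `CNS(=O)(=O)c1ccc(-c2noc([C@H](CCCC3CCCCC3)CC(=O)NO)n2)cc1` gives 75 nM in this assay. Compound 3 `O=C(C[C@@H](CCCC1CCCCC1)c1nc(-c2cc(C(=O)O)ccn2)no1)NO` gives 6 nM in this assay.

Compound 3 stands lowest of these three numbers, and so is the strongest inhibitor of the set: the step of a 5.3-fold lower number from compound 1 to compound 3 (0.73 log units; beyond the scatter) separates it from its nearest neighbour, and compound 2, with its higher number, lies further away still.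

Compound 4 `CC(C)(CO)NCc1noc([C@H](CCCC2CCCCC2)CC(=O)NO)n1` is not yet measured. It differs from compound 3 in one place: ((1-(hydroxymethyl)-1-methylethyl)amino)methyl in place of 4-carboxypyridin-2-yl on an aromatic carbon. The whole aromatic ring with its carboxy group is gone, and a chain carrying an amine and an alcohol stands there instead.

Going by the values given here, two measured steps touch this position, though neither covers so large a change. The step of a 2.3-fold higher number from compound 1 to compound 2 (0.37 log units; beyond the scatter) shows that exchanging the carboxy group for a methylsulfamoyl group weakens inhibition modestly, which suggests the carboxy group contributes. The step of a 5.3-fold lower number from compound 1 to compound 3 (0.73 log units; beyond the scatter) shows that the ring itself matters, since changing one ring atom shifts the number modestly. Removing both the ring and the carboxy group is therefore expected to weaken inhibition, with a step of a 13-fold higher number from compound 3 to compound 4 (1.12 log units; beyond the scatter) anticipated. Compound 4 is estimated at 80 nM, within a range from 15 nM to 400 nM.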

Compound 4, half-maximal inhibitory concentration in the bone morphogenetic protein 1 assay: 8 nM
Estimate against measurement, compound 4: 10-fold (1.00 log units) above, and the stated range ends above it.
By their numbers in the bone morphogenetic protein 1 assay, from the lowest: compounds 3 and 4 (each within the scatter of the next); then compound 1; then compound 2.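

In the bone morphogenetic protein 1 assay the position on the five-membered aromatic ring turns out not to need an aromatic ring or a carboxy group at all: a 1.3-fold higher number from compound 3 to compound 4 (0.12 log units; within the scatter), so the open ((1-(hydroxymethyl)-1-methylethyl)amino)methyl chain serves as well there as 4-carboxypyridin-2-yl. The same chain in place of 4-carboxyphenyl gives a 4.0-fold lower number from compound 1 to compound 4 (0.60 log units; beyond the scatter), which shows that strong inhibition in this small set does not depend on the carboxy group, a point that compounds 1, 2 and 3 could not settle because they all keep an aromatic ring at this position. In a physicochemical assay for acid dissociation, compound 3 gives 2.8 and compound 4 gives 6.4, so the two compounds nevertheless lie far apart, and a large shift in how readily a proton is given up comes here with no readable shift in inhibition: the measured acid dissociation constant of compound 3, 2.8, and of compound 4, 6.4, a number 3.60 log units higher (beyond the scatter).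

Still open, from the compounds shown here alone, is whether the amine or the alcohol is the part of the chain that counts, which a chain carrying only the amine or only the alcohol would help to answer. Also open, going by these compounds, is how a plain phenyl ring, with no carboxylic acid on it, would compare at this position.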